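The source may hold more compounds than are shown below. What is called first, only, known or untested is meant among the compounds shown, and "the series" means these compounds.

Measured compounds:
compound 1, `COc1ccc(C2=C(c3cc(OC)c(OC)c(OC)c3)C(=O)C(OC(C)=O)C2)cc1`, 72 ug/mL
compound 2, `COc1ccc(C2=C(c3cc(OC)c(OC)c(OC)c3)C(=O)C(O)C2)cc1`, < 1 ug/mL
compound 3, `COc1cc(C2=C(c3cc(C)c(OC)c(C)c3)C(O)CC2=O)cc(OC)c1OC`, > 100 ug/mL

All three were tested in an ADME assay on KB cells (Homo sapiens) for cytotoxicity, read by MTT assay, with a stated time of 72 h; on this read-out lower numbers stand for stronger inhibition and higher numbers for weaker inhibition. For compound 2 the figure < 1 ug/mL is the limit of < 1 ug/mL in this assay, at which 1 of the 3 values shown sits, not a number. For compound 3 the figure > 100 ug/mL is the limit of > 100 ug/mL in this assay, at which 1 of the 3 values shown sits, again not a number. Compound 1 and compound 2 share a core and differ in one place: acetyl in place of hydrogen on an oxygen on a saturated carbon. This change made an at least 72-fold higher number from compound 2 to compound 1 (1.85 log units; beyond the scatter), so the acetyl compound gave a much weaker result than the hydroxy compound in this pair.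

The core of compound 3 differs from the core of compound 2 in more than one place, and that difference is not broken down here. Compound 4, `COc1cc(C2=C(c3cc(C)c(OC)c(C)c3)C(OC(C)=O)CC2=O)cc(OC)c1OC`, has not yet been measured; it stands to compound 3 as compound 1 stands to compound 2: acetyl in place of hydrogen on an oxygen on a saturated carbon. The place of the change reads the same word for word in both pairs, so this is the same change made on a different core.

Among the measured compounds shown here, compound 3 already gives only a limit in this assay, and the one earlier instance of this change weakened cytotoxicity sharply. Compound 4 is therefore expected to give 150 ug/mL, most likely again as a limit rather than a number, with a plausible span from 60 ug/mL to 400 ug/mL. The step this estimate implies is a step that the limit leaves unreadable from compound 3 to compound 4, which cannot be read exactly because compound 3 itself gives only a limit.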

Compound 4, half-maximal inhibitory concentration: > 100 ug/mL
Compound 4 ended at the assay's limit; the forecaster's own chance of this, stated with the estimate: 85%; the middle value does not contradict the limit.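

In this assay compound 4 gives > 100 ug/mL, a limit and not a number. Compound 3 gives > 100 ug/mL, likewise a limit. No step can be read between compound 3 and compound 4, because both sit at the same limit: the limit of > 100 ug/mL in this assay, at which 2 of the 4 values shown sit.

The compounds shown leave open whether acetyl in place of hydrogen changes the result at all on the core of compound 3.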